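A few compounds are considered here, and "the series" means these few. Any claim that something is new, unique, unknown or untested is made for them only; others in the source may bear on it.

In a functional assay on HepG2 cells (Homo sapiens) for antiproliferative activity, read by MTT assay, with a stated time of 24 h (on this read-out higher numbers stand for weaker inhibition and lower numbers for stronger inhibition), compound 1 (`COc1ccc(C(=O)/C=C/c2ccc(Br)cc2)c2c1C=CC(C)(C)O2`) gives > 10000 nM as a limit and not a number. Compound 2 (`COc1ccc(C(=O)/C=C/c2ccccc2)c2c1C=CC(C)(C)O2`) gives > 10000 nM in this assay as a limit too. Compound 3 (`COc1ccc(C(=O)/C=C/c2cccc(Cl)c2)c2c1C=CC(C)(C)O2`) stands at > 10000 nM in this assay and this is again only a limit. Among the compounds with values here, the series so far therefore sits together (the limit of > 10000 nM in this assay, at which 3 of the 3 values shown sit).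

Compound 4 (`COc1ccc(C(=O)/C=C/c2cccc(O)c2)c2c1C=CC(C)(C)O2`) carries hydroxy in place of chloro on an aromatic carbon, meta to a large group (hydroxy in place of chloro on an aromatic carbon). The same difference reads 3-chlorophenyl to 3-hydroxyphenyl.

Within the data shown here, three measured steps bear on this change: (a step that the two limits leave unreadable from compound 2 to compound 3), (a step that the two limits leave unreadable from compound 1 to compound 3) and (a step that the two limits leave unreadable from compound 1 to compound 2). None of them has a readable size, so none supplies a size or direction to carry over. No step beyond the scatter is expected in this assay on this evidence, in either direction. The expected step is (a step that the limit leaves unreadable from compound 3 to compound 4) and remains an estimate. The estimate for compound 4 is 15000 nM with an expected range from 5000 nM to 50000 nM in this assay as the working figure.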

Compound 4, half-maximal inhibitory concentration: > 10000 nM
Compound 4: only a limit was reported (the forecaster's own chance of this, stated with the estimate: 70%); the middle value does not contradict the limit.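

In this assay no step can be read between compound 4 and compound 1, compound 2 or compound 3, and the series stays together at one limit: the limit of > 10000 nM in this assay, at which 4 of the 4 values shown sit. The compounds shown leave open how far apart these four lie and which change, if any, moves this read-out.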